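A few compounds are considered here, and "the series" means these few. Any claim that something is new, unique, unknown or untested is made for them only; others in the source may bear on it.

Compound 1 `c1ccc2cc(CO[C@@H]3CCNC3)ccc2c1` has the higher of the two numbers measured in an assay on HEK293 cells for inhibition of sodium-dependent dopamine transporter (Homo sapiens) (a lower number here means a stronger inhibitor, a higher number a weaker inhibitor), where compound 1 gives 3800 nM. Among the compounds with values here, compound 2 `Fc1ccc2cc(CO[C@@H]3CCNC3)ccc2c1` gives 2100 nM, and the single measured step is a 1.8-fold lower number from compound 1 to compound 2 (0.26 log units; within the scatter). Compound 3 `c1ccc2cc(CO[C@H]3CCNC3)ccc2c1` differs from compound 1 in this way: the two compounds have the same atoms and bonds and differ only in configuration as drawn: 1 of 1 stereo elements differ; a stereocentre at a saturated ring carbon is drawn R in compound 1 and S in compound 3. That one measured step concerns a fluoro substitution, not a change of configuration, so nothing measured here tells how large such a change will be or in which direction. For compound 3 the value expected in this assay is 3000 nM, within a wide range from 500 nM to 15000 nM, an expected step of a 1.3-fold lower number from compound 1 to compound 3 (0.10 log units; within the scatter).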

Compound 3, half-maximal inhibitory concentration: 15000 nM
For compound 3 the middle estimate is 5.0-fold (0.70 log units) below the measured one; the range from low to high includes it.
By their numbers in this assay, from the lowest: compounds 2 and 1 (each within the scatter of the next); then compound 3.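

In this assay, the configuration at this saturated ring carbon matters: going from R to S gives a 3.9-fold higher number from compound 1 to compound 3 (0.60 log units; beyond the scatter). The fluoro step stayed within the scatter, so this is the first change shown that clearly moves the number, and here the higher number means a weaker inhibitor. The shift can be assigned to the stereocentre alone because nothing else changes: the fact that compounds 1 and 3 differ only in the configuration as drawn

Still open, going by these compounds, is whether the same preference for R holds with the fluoro group of compound 2 in place. On these data alone, it is also open whether a chloro or methoxy group in place of that fluoro would move the number beyond the scatter.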